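A few compounds are considered here, and "the series" means these few. Any claim that something is new, unique, unknown or untested is made for them only; others in the source may bear on it.

Among the measured compounds shown here, in a functional assay on MDA-MB-435 cells (Homo sapiens) for cytotoxicity, read by MTT assay, with a stated time of 72 h (a higher number here means a weaker inhibitor, a lower number a stronger inhibitor), three compounds on a shared core have numbers so far. Compound 1 (`NCCCNc1c(C(=O)NCc2ccc(F)cc2)nc(Br)c2cccnc12`) gives 5000 nM and compound 2 (`COc1cccc(CNC(=O)c2nc(Br)c3cccnc3c2N[C@H]2CC[C@H](N)CC2)c1`) gives 7000 nM on this measure. Compound 3 (`N[C@H]1CC[C@H](Nc2c(C(=O)NCc3ccc(F)cc3)nc(Br)c3cccnc23)CC1`) gives 6000 nM and so stands within the usual scatter of both others, with no order to be read among the three.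

Compound 4 (`C[C@H](NC(=O)c1nc(Br)c2cccnc2c1N[C@H]1CC[C@H](N)CC1)c1ccc(F)cc1`) departs from compound 3 in one place, namely methyl in place of hydrogen on a saturated chain carbon bound to an amide-type nitrogen and an aromatic carbon with methyl in place of hydrogen on a saturated chain carbon bound to an amide-type nitrogen and an aromatic carbon, so that 4-fluorobenzyl becomes 1-(4-fluorophenyl)ethyl.

For the measured compounds named here, no measured step makes this change, and two bear on it only loosely. Putting 4-fluorophenyl in place of 3-methoxyphenyl on a saturated chain carbon bound to an amide-type nitrogen gave a 1.2-fold lower number from compound 2 to compound 3 (0.07 log units; within the scatter) and putting 4-aminocyclohexyl in place of 3-aminopropyl on a nitrogen on an aromatic ring gave a 1.2-fold higher number from compound 1 to compound 3 (0.08 log units; within the scatter) at a different place. Going by the values given here, both stayed within the scatter, and nothing measured so far tests a methyl at this carbon. No step beyond the scatter is therefore expected in this assay and no direction is favoured. The expected step is no change at the digits printed from compound 3 to compound 4 (within the scatter) with real uncertainty around it. Compound 4 is estimated at 6000 nM with an expected range from 2500 nM to 12000 nM overall.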

Compound 4, half-maximal inhibitory concentration: > 10000 nM
Compound 4 gave a limit, no number; the forecaster's own chance of this, stated with the estimate: 10%; at least 1.6-fold (0.22 log units) between middle value and limit.
By their numbers in this assay, from the lowest: compounds 1, 3 and 2 (each within the scatter of the next). At a limit, above all of these: compound 4.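

In this assay compound 4 gives a limit and not a number, the only such reading among the compounds shown: the limit of > 10000 nM in this assay, at which 1 of the 4 values shown sits.

Putting methyl in place of hydrogen on this saturated chain carbon gave an at least 1.6-fold higher number from compound 3 to compound 4 (0.22 log units; that floor lies within the scatter), and putting 1-(4-fluorophenyl)ethyl in place of 3-methoxybenzyl on the amide-type nitrogen gave an at least 1.4-fold higher number from compound 2 to compound 4 (0.15 log units; that floor lies within the scatter). This is the first change among the compounds shown to end at a limit rather than at a number, whereas the earlier steps at the aromatic ring of the benzyl group and on the nitrogen on the aromatic ring stayed within the scatter, but both new floors also lie within the scatter, so the step cannot be said to exceed it and its true size stays unknown.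

The compounds shown do not tell whether an ethyl, a hydroxymethyl or a second methyl on this carbon would give a number or a limit. They also leave open whether the same methyl would read alike with the 3-aminopropyl of compound 1 or the 3-methoxyphenyl of compound 2.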